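Extending a hydroxyalkyl chain on a fused pyrimidinedione core

A few compounds are considered here, and "the series" means these few. Any claim that something is new, unique, unknown or untested is made for them only; others in the source may bear on it.

Measured compounds:
- compound 1, `CC(C)Cn1c(=O)n(C)c(=O)c2nc(CCCCO)c(Cc3cccc4ccccc34)nc21`: > 2000 nM
- compound 2, `CC(C)Cn1c(=O)n(C)c(=O)c2nc(CCCCCO)c(Cc3cccc4ccccc34)nc21`: 192 nM
- compound 3, `CC(C)Cn1c(=O)n(C)c(=O)c2nc(-c3c(CCCO)nnn3C)c(Cc3cccc4ccccc34)nc21`: "not determined" (no result reported)

In an assay on MCF7 cells for inhibition of Monocarboxylate transporter 1 (Homo sapiens), read by scintillation counting, with a stated time of 10 min (on this read-out lower numbers stand for stronger inhibition and higher numbers for weaker inhibition), compound 1 gives only a limit, > 2000 nM, so its true value is not known. Compound 2 gives 192 nM in this assay. Among the measured compounds shown here, the step of an at least 10-fold lower number from compound 1 to compound 2 (1.01 log units; beyond the scatter) is the one measured change here, and it is large, pointing to a longer hydroxy chain giving a lower number. Compound 3 has no number in this assay, so it cannot be placed against compounds 1 and 2.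

Compound 4, `CC(C)Cn1c(=O)n(C)c(=O)c2nc(/C=C\CCCO)c(Cc3cccc4ccccc34)nc21`, differs from compound 3 by 5-hydroxypent-1-en-1-yl in place of 4-(3-hydroxypropyl)-1-methyl-1H-1,2,3-triazol-5-yl on an aromatic carbon. The chain that enters is an unsaturated five-carbon chain ending in a hydroxy group, close in length to the chain of compound 2, and clearly longer than the chain of compound 1, which sits at the limit (the limit of > 2000 nM in this assay, at which 1 of the 3 values shown sits). Because the step of an at least 10-fold lower number from compound 1 to compound 2 (1.01 log units; beyond the scatter) favours the longer chain, compound 4 is expected to land near compound 2 rather than at the limit. Compound 4 is therefore estimated at 350 nM in this assay, with a range of 90 nM to 1500 nM.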

Compound 4, half-maximal inhibitory concentration: 116 nM
Estimate against measurement, compound 4: 3.0-fold (0.48 log units) above; low and high end bracket the measured number.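

In this assay, putting a double bond into the chain gives a 1.7-fold lower number from compound 2 to compound 4 (0.22 log units; within the scatter), so 5-hydroxypent-1-en-1-yl and 5-hydroxypentyl cannot be told apart at this position. The second step, an at least 17-fold lower number from compound 1 to compound 4 (1.23 log units; beyond the scatter), shows that the large difference from 4-hydroxybutyl also holds for a chain with a double bond, so it is not specific to the saturated 5-hydroxypentyl chain. Compound 1 still gives only a limit, not a number: the limit of > 2000 nM in this assay, at which 1 of the 4 values shown sits.

The compounds shown leave open whether a longer chain would lower the number further or whether the trend stops at this length. They also leave open whether the terminal hydroxy group itself matters, which an amine or a carboxylic acid at the chain end could test.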